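From Pyridin-3-yl to Pyridin-4-yl on a Shared Core

A few compounds are considered here, and "the series" means these few. Any claim that something is new, unique, unknown or untested is made for them only; others in the source may bear on it.

Three measured compounds share one core and differ mainly in the group attached to a carbon with a double bond to nitrogen. Compound 1 `Fc1ccc(-c2csc(N/N=C\c3ccncc3)n2)cc1` carries a pyridin-4-yl group; in an in vitro assay on BTI-TN-5B1-4 cells for inhibition of Amine oxidase [flavin-containing] A (Homo sapiens), read by Amplex Red, with a stated time of 15 min, tested at 100 uM (on this read-out lower numbers stand for less inhibition and higher numbers for more inhibition at the one concentration tested (going by the name of the read-out)), compound 1 gives 40%. Compound 2 `Fc1ccc(-c2csc(N/N=C\c3cccs3)n2)c(F)c1` carries a thiophen-2-yl group and a second fluorine on the core; in this assay compound 2 gives 40%. Compound 3 `Fc1ccc(-c2csc(N/N=C\c3cccnc3)n2)c(F)c1` keeps that second fluorine and carries a pyridin-3-yl group; in this assay compound 3 gives 40%. Compound 3 thus stands level with compound 1 and compound 2 at the digits shown. For the measured compounds named here, the only single-point step among them is no change at the digits printed from compound 2 to compound 3 (within the scatter).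

Compound 4 `Fc1ccc(-c2csc(N/N=C\c3ccncc3)n2)c(F)c1` has not yet been measured. It differs from compound 3 in one place: pyridin-4-yl in place of pyridin-3-yl on a carbon with a double bond to nitrogen. The step from compound 2 to compound 3 swapped one ring for another at this same carbon without moving the read-out, and compound 1, which already holds pyridin-4-yl on a core with one fluorine, shows the same value as compound 3. Nothing here points to a shift beyond the scatter, so the step of no change at the digits printed from compound 3 to compound 4 (within the scatter) is expected to be flat. Compound 4 is therefore estimated to give 40% in this assay, with a likely range from 25% to 55%.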

Compound 4, a percentage reported as inhibition, at one concentration (the size of the read-out at that concentration, not a potency): "not active" (no number reported)
No number was reported for compound 4; the estimate stays without a comparison.
By their numbers in this assay, from the lowest: compounds 1, 2 and 3 (each within the scatter of the next).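

In this assay, for the compounds shown here, compound 4 is reported only as not active, with no number, so no step from compound 3 to compound 4 can be read. No available evidence bears on this result. The compounds shown leave open whether swapping pyridin-3-yl for pyridin-4-yl on this core truly changes inhibition.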